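The compounds below may be only part of what the source reports. "The series", "measured", "known", "first", "only" and "open" are said of these compounds alone.

Measured so far in a functional assay for agonist activity at G protein-coupled receptor 88 (Homo sapiens), read by HTRF and cAMP accumulation; on this read-out higher numbers stand for an effect only at larger amounts of compound and lower numbers for an effect already at smaller amounts:
compound 1 `CC[C@H](C)[C@H](N)CN(C(=O)[C@@H]1C[C@H]1c1cccc(F)c1)c1ccc(-c2ccccc2)cc1` — 560 nM
compound 2 `CC[C@H](C)[C@H](N)CN(C(=O)[C@@H]1C[C@H]1c1ccccn1)c1ccc(-c2ccccc2)cc1` — 130 nM

Compound 2 stands at the lower of the two numbers in this assay, with 130 nM. Among the measured compounds shown here, the only other point is compound 1, which in this assay gives 560 nM, and the gap between the two is beyond the scatter.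

Compound 3 `CC[C@H](C)[C@H](N)CN(C(=O)[C@@H]1C[C@H]1c1ccncc1)c1ccc(-c2ccccc2)cc1` has not been measured. It differs from compound 2 in one place: pyridin-4-yl in place of pyridin-2-yl on a saturated ring carbon. The substituent keeps its size and its single ring nitrogen; only the position of that nitrogen within the ring moves.

For the measured compounds named here, one measured step bears on this site. It is a 4.3-fold lower number from compound 1 to compound 2 (0.63 log units; beyond the scatter), and it exchanged the whole ring rather than shifting the nitrogen inside it. Going by the values given here, no step on record tells how the two pyridyl isomers compare, so the expected size of the change cannot be read from the data and is set at about the scatter, with a wide range. The number for compound 3 in this assay is therefore estimated at 260 nM, between 80 nM and 900 nM, which corresponds to an expected step of a 2.0-fold higher number from compound 2 to compound 3 (0.30 log units; within the scatter).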

Compound 3, half-maximal effective concentration: 1500 nM
The estimate for compound 3 lay 5.8-fold (0.76 log units) below the measured number, and the stated range ends below it.
By their numbers in this assay, from the lowest: compound 2; then compound 1; then compound 3.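

In this assay, the position of the ring nitrogen alone accounts for a 12-fold higher number from compound 2 to compound 3 (1.06 log units; beyond the scatter) and this large step comes with no change in heavy atoms, ring size or counted hydrogen-bond groups, so this site on the cyclopropane distinguishes pyridin-2-yl from pyridin-4-yl sharply. The earlier result therefore cannot be read as a gain from any pyridyl ring in place of 3-fluorophenyl: a 4.3-fold lower number from compound 1 to compound 2 (0.63 log units; beyond the scatter) is set against a 2.7-fold higher number from compound 1 to compound 3 (0.43 log units; beyond the scatter) and the two exchanges move the number in opposite directions. Nothing measured here gives a reason for the gap between the two pyridyl isomers.

The compounds shown leave open where pyridin-3-yl would fall relative to the two isomers in hand, and so whether the number changes stepwise as the nitrogen moves around the ring. They also leave open whether a methyl, methoxy or amino group on the pyridin-2-yl ring would keep, improve or lose the standing of compound 2 in this series.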